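Switching the amine ring on the shared core of compound 3

The compounds below may be only part of what the source reports. "The series", "measured", "known", "first", "only" and "open" are said of these compounds alone.

Measured compounds:
compound 1: `O=C(CCc1ccc(C(F)(F)F)cc1)Nc1ccc2nc(N3CCC3)ccc2c1`, 56 nM
compound 2: `CC1CCN(c2ccc3cc(NC(=O)CCc4ccc(C(F)(F)F)cc4)ccc3n2)C1`, 400 nM
compound 3: `O=C(CCc1ccc(C(F)(F)F)cc1)Nc1ccc2nc(N3CCC4(CCNC4)C3)ccc2c1`, 140 nM

In a functional assay on HEK293 cells for activation of melanin-concentrating hormone receptor 1 (Rattus norvegicus), read by inositol phosphate accumulation (a higher number here means that more compound is needed for the effect, a lower number that less compound is needed), compound 3 stands second highest of the three numbers. Its nearest neighbour is compound 1, reached by a 2.5-fold higher number from compound 1 to compound 3 (0.40 log units; beyond the scatter); furthest from it is compound 2, with a 2.9-fold lower number from compound 2 to compound 3 (0.46 log units; beyond the scatter). The remaining step, a 7.1-fold higher number from compound 1 to compound 2 (0.85 log units; beyond the scatter), shows the larger of the two single-ring amines giving the highest number of the set.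

Compound 4, `NC1CCN(c2ccc3cc(NC(=O)CCc4ccc(C(F)(F)F)cc4)ccc3n2)C1`, is reached from compound 3 by a group of 6 heavy atoms (4 carbon, 2 nitrogen; one five-membered non-aromatic ring with 1 hetero atom) in place of a group of 9 heavy atoms (7 carbon, 2 nitrogen; 2 five-membered non-aromatic rings with 1 hetero atom each), on an aromatic carbon. The step from compound 2 to compound 3 bears most on this change, since it compares a single five-membered ring with the two-ring group; that step was modest and it went downward, so the reverse direction is expected here. The step from compound 1 to compound 3 points the other way, toward a smaller group giving a lower number, but the smaller group there was a four-membered ring. For the measured compounds named here, no measured pair tells what the amino group on the ring does in place of a methyl group. Compound 4 is therefore expected to give a modestly higher number than compound 3, with a 1.6-fold higher number from compound 3 to compound 4 (0.20 log units; within the scatter), its estimate being 220 nM within 70 nM to 700 nM.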

Compound 4, half-maximal effective concentration: 200 nM
Estimate against measurement, compound 4: 1.1-fold (0.04 log units) above; measured number inside the range.
By their numbers in this assay, from the lowest: compound 1; then compounds 3, 4 and 2 (each within the scatter of the next, the first and the last beyond it).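

In this assay the two-ring group gives way to the single-ring 3-aminopyrrolidin-1-yl with a 1.4-fold higher number from compound 3 to compound 4 (0.15 log units; within the scatter) and so, at this place next to the ring nitrogen, the second ring is not needed to hold this level. For the compounds shown here, the swap of amino for methyl on the saturated ring carbon, which no earlier pair isolated, gives a 2.0-fold lower number from compound 2 to compound 4 (0.30 log units; within the scatter) and so does not separate the two groups. Azetidin-1-yl also stands apart from the new amine, with a 3.6-fold higher number from compound 1 to compound 4 (0.55 log units; beyond the scatter) so that the four-membered ring keeps the lowest number of the set.

The compounds shown leave open how a piperidin-1-yl or dimethylamino group would read at this place, and what an amino group on the four-membered ring would do. Nothing measured here offers a reason for these steps.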